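The source may report more compounds than this note shows. Statements on the series, on what has been measured and on what is new or still open speak of the compounds shown alone.

Compound 1 `CCC(C)(C)Cc1c[nH]c(CCc2ccc(N3CCCCC3)cc2)n1` and compound 2 `O=C(O)c1cc(F)c(F)cc1-c1ccc(CCc2nc(CC3CCCCC3)c[nH]2)cc1` share an imidazole core joined through a two-carbon chain to a phenyl ring, and both were tested in a functional assay on HEK293 cells for agonist activity at Bombesin receptor subtype-3 (Homo sapiens), read by luminescence and calcium flux, with a stated time of 10 min; a higher number here means that more compound is needed for the effect, a lower number that less compound is needed. Compound 1 gives 108 nM, and compound 2 gives 103 nM; the two numbers lie within the scatter of each other, so neither compound can be set above the other on this evidence. Compound 3 `CCC(C)(C)Cc1c[nH]c(CCc2ccc(-n3cncn3)cc2)n1` is the next variation on compound 1. The change is 1H-1,2,4-triazol-1-yl in place of piperidin-1-yl on an aromatic carbon. Among the compounds with values here, no measured pair in this small set isolates such an exchange, so the expectation rests on the two numbers alone. Because compound 1 sits at 108 nM and the exchange removes a saturated amine ring in favor of a small aromatic heterocycle, a modest worsening is expected, as a step of a 2.4-fold higher number from compound 1 to compound 3 (0.38 log units; beyond the scatter). Compound 3 is therefore estimated at 260 nM, with a likely range from 80 nM to 900 nM in this assay.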

Compound 3, half-maximal effective concentration: 89 nM
Estimate against measurement, compound 3: 2.9-fold (0.47 log units) above; the range from low to high includes it.
By their numbers in this assay, from the lowest: compounds 3, 2 and 1 (each within the scatter of the next).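

In this assay, within the data shown here, placing 1H-1,2,4-triazol-1-yl in place of piperidin-1-yl on an aromatic carbon, para to a large group, gives a 1.2-fold lower number from compound 1 to compound 3 (0.08 log units; within the scatter), the first reading of a change at one place. At this position, a six-membered non-aromatic ring and a five-membered aromatic ring with three hetero atoms therefore read alike, despite their different hydrogen-bond acceptor counts. No measurement shown explains why the two groups read alike.

The compounds shown leave open whether this position would read the same with a simple amine, a carboxylic acid or a lone fluorine atom in place of these rings. They also leave open whether a longer chain in place of the two-carbon link would keep the reading of compound 3 at this level.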